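The source may report more compounds than this note shows. Statements on the series, on what has been measured and on what is new or still open speak of the compounds shown alone.

The values come from a functional assay on A549 cells (Homo sapiens) for cytotoxicity, read by MTT assay, with a stated time of 4 days; a lower number here means a stronger inhibitor, a higher number a weaker inhibitor.
Compound 1, `C=C1C[C@]23C[C@@]1(O)CC[C@@H]2c1cccc(C)c1[C@@H]3Cn1cc(-c2ccc(C)cc2)nn1`, gives > 20000 nM, which is a limit of the assay and not a number.
Compound 2, `C=C1C[C@]23C[C@@]1(O)CC[C@@H]2c1cccc(C)c1[C@@H]3Cn1cc(-c2ccc(Br)cc2)nn1`, gives > 20000 nM, again only a limit.
Compound 3, `C=C1C[C@]23C[C@@]1(O)CC[C@@H]2c1cccc(C)c1[C@@H]3Cn1cc(-c2ccc(F)cc2)nn1`, gives > 20000 nM, once more only a limit.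

Compound 3 therefore stands at a limit in this assay and nowhere else, and the two further values shown are limits as well, since all three sit at the limit of > 20000 nM in this assay, at which 3 of the 3 values shown sit. Compound 4, `C=C1C[C@]23C[C@@]1(O)CC[C@@H]2c1cccc(C)c1[C@@H]3Cn1cc(-c2ccccn2)nn1`, differs from compound 3 in one place: pyridin-2-yl in place of 4-fluorophenyl on an aromatic carbon. Three measured steps connect the measured compounds, and none of them can be read: a step that the two limits leave unreadable from compound 1 to compound 2, a step that the two limits leave unreadable from compound 1 to compound 3 and a step that the two limits leave unreadable from compound 2 to compound 3 each run between two limits, so neither their size nor their direction is known. So far, exchanging the group on that aromatic carbon of the five-membered aromatic ring with three nitrogen has never brought a value off the limit in this assay.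

Within the data shown here, no measured step thus gives a readable size for the change from compound 3 to compound 4, and the expectation in this assay is that compound 4 is most likely reported at the limit again, with no step beyond the scatter readable. Compound 4 is expected to give about 30000 nM, between 10000 nM and 100000 nM. The step this estimate means, a step that the limit leaves unreadable from compound 3 to compound 4, is expected to be small or unreadable.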

Compound 4, half-maximal inhibitory concentration: > 20000 nM
Compound 4 was reported as a limit; the forecaster's own chance of this, stated with the estimate: 85%; the middle value lies beyond the limit too.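

In this assay compound 4 gives > 20000 nM, a limit and not a number, so its steps to compound 1, compound 2 and compound 3 cannot be read. The compounds shown leave open whether exchanging the group on that aromatic carbon changes the value at all, or by how much: the limit of > 20000 nM in this assay, at which 4 of the 4 values shown sit.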